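Swapping Pentyl for Pentyloxy on a Cyclohexyl Analogue

The source may hold more compounds than are shown below. What is called first, only, known or untested is meant among the compounds shown, and "the series" means these compounds.

Compound 1 `CCCCCc1ccc(-c2c(C)[nH]c(=O)n2C)cc1` and compound 2 `CCCCCOc1ccc(-c2c(C)[nH]c(=O)n2C)cc1` share one core and differ in a single place: pentyloxy in place of pentyl on an aromatic carbon. In a functional assay on brain (Rattus norvegicus, strain Wistar) for inhibition (a lower number here means a stronger inhibitor, a higher number a weaker inhibitor), compound 1 gives 5900 nM, and compound 2 gives 4500 nM; the step was a 1.3-fold lower number from compound 1 to compound 2 (0.12 log units; within the scatter). Compound 3 `CCCCCc1ccc(-c2c(C)[nH]c(=O)n2C2CCCCC2)cc1` has a different core from compound 1: cyclohexyl in place of methyl on an aromatic nitrogen. In this assay compound 3 gives 10600 nM, a step of a 1.8-fold higher number from compound 1 to compound 3 (0.25 log units; within the scatter). Compound 4 `CCCCCOc1ccc(-c2c(C)[nH]c(=O)n2C2CCCCC2)cc1` is not yet measured and differs from compound 3 in pentyloxy in place of pentyl on an aromatic carbon. For the measured compounds named here, this is the same kind of change as the one from compound 1 to compound 2, though the surroundings are described differently: in the earlier pair the group sits para to a group of 8 heavy atoms, in the present pair para to a large group. The earlier instance stayed within the scatter, and nothing here suggests the new core would alter that. The step from compound 3 to compound 4 is therefore expected to be a 1.2-fold lower number from compound 3 to compound 4 (0.10 log units; within the scatter), set beside the earlier 1.3-fold lower number from compound 1 to compound 2 (0.12 log units; within the scatter). The estimate for compound 4 in this assay is 8500 nM, expected to fall between 4000 nM and 18000 nM.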

Compound 4, half-maximal inhibitory concentration: 9100 nM
Compound 4: middle estimate off by 1.1-fold (0.03 log units), on the low side; low and high end bracket the measured number.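

In this assay, pentyloxy in place of pentyl gives a 1.2-fold lower number from compound 3 to compound 4 (0.07 log units; within the scatter) on the cyclohexyl-bearing core, and this small step matches the one seen on the core of compound 1: the same change on two cores in this assay, a 1.3-fold lower number (0.12 log units; within the scatter) from compound 1 to compound 2 and a 1.2-fold lower number (0.07 log units; within the scatter) from compound 3 to compound 4, 1.1-fold (0.05 log units) apart, within the scatter of two such steps. Read the other way, cyclohexyl in place of methyl on the aromatic nitrogen gives a 2.0-fold higher number from compound 2 to compound 4 (0.31 log units; beyond the scatter) with pentyloxy present, and this too matches its earlier counterpart: the same change on two cores in this assay, a 1.8-fold higher number (0.25 log units; within the scatter) from compound 1 to compound 3 and a 2.0-fold higher number (0.31 log units; beyond the scatter) from compound 2 to compound 4, 1.1-fold (0.05 log units) apart, within the scatter of two such steps. Together, the two comparisons show that each change behaved alike in both settings among these four compounds, but they rest on one pair per core, and the pentyl to pentyloxy step is itself within the scatter, so they do not show that a larger effect would carry over or that other cores would behave the same way.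

The compounds shown leave open what a longer chain, or an amine in place of the pentyl chain, would do on either core. They also leave open how ethyl or benzyl on the aromatic nitrogen would compare with methyl and cyclohexyl.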